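The source may report more compounds than this note shows. Statements on the series, on what has been measured and on what is new or still open speak of the compounds shown alone.

Measured so far in an ADME assay for permeability, using PAMPA, with a stated time of 4 h, at pH 7.4; a lower number here means that the compound crosses the layer more slowly, a higher number that the compound crosses the layer faster:
- compound 1 `CN(C)C1CCN(c2cccc3c2C[C@H](CN(C)[C@H]2CCCc4cccnc42)NC3)CC1`: 44 nm/s
- compound 2 `CN1CC[C@H]2CN(c3cccc4c3C[C@H](CN(C)[C@H]3CCCc5cccnc53)NC4)C[C@H]21`: 9 nm/s

Of these two, compound 2 has the lower number, and the gap to compound 1 lies beyond the scatter. Within the data shown here, the next compound is compound 3 `CN(C[C@H]1Cc2c(cccc2N2C[C@H]3CCN(C)[C@H]3C2)CN1)[C@H]1CCCc2cccnc21`. the two compounds have the same atoms and bonds and differ only in configuration as drawn: 2 of 4 stereo elements differ; a stereocentre at a saturated ring carbon is drawn S in compound 2 and R in compound 3; a stereocentre at a saturated ring carbon is drawn S in compound 2 and R in compound 3 Only one measured step bears on this, and only indirectly: a 4.9-fold lower number from compound 1 to compound 2 (0.69 log units; beyond the scatter). That step put a different group on an aromatic carbon, whereas compound 3 has the same atoms and bonds as compound 2. Among the measured compounds shown here, no measured pair differs in configuration alone, so the size of this change in this assay remains untested. The best guide is compound 2 itself, at 9 nm/s, and no step beyond the scatter is expected. Compound 3 is estimated at 10 nm/s, with an expected range of 4 nm/s to 25 nm/s. The expected change is a 1.1-fold higher number from compound 2 to compound 3 (0.05 log units; within the scatter).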

Compound 3, apparent permeability: 19 nm/s
Compound 3: middle estimate off by 1.9-fold (0.28 log units), on the low side; measured number inside the range.
By their numbers in this assay, from the lowest: compound 2; then compound 3; then compound 1.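

In this assay the result gives the first measured effect of configuration alone, with a 2.1-fold higher number from compound 2 to compound 3 (0.32 log units; beyond the scatter), and this step can be assigned to the two saturated ring stereocentres because of one fact: the fact that compounds 2 and 3 differ only in the configuration as drawn. The group with two five-membered non-aromatic rings therefore does not set the number through its atoms and bonds alone. Measured against the group with one six-membered non-aromatic ring, the gap depends on the configuration drawn, going from a 4.9-fold lower number from compound 1 to compound 2 (0.69 log units; beyond the scatter) to a 2.3-fold lower number from compound 1 to compound 3 (0.36 log units; beyond the scatter), and both steps leave compound 1 with the higher number.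

On these data alone, the two stereocentres differ together, so the share of each in the step remains open. As far as these compounds go, it is also open how a piperazine or a morpholine on the same aromatic carbon would compare.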